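The compounds below may be only part of what the source reports. "The series", "measured", "known", "first", "only" and "open" are said of these compounds alone.

Measured so far:
compound 1, `O=Cc1ccc(-c2cn3ccnc3c(-c3ccc4ncn(C5CCCCC5)c4c3)n2)cc1`, in a functional assay on NCI-H460 cells (Homo sapiens) for inhibition, read by sulforhodamine B assay, with a stated time of 48 h, tested at 10 uM (on this read-out lower numbers stand for less inhibition and higher numbers for more inhibition at the one concentration tested (going by the name of the read-out)), compound 1 gives 37.8%;
compound 2, `Clc1ccc(-c2cn3ccnc3c(-c3ccc4ncn(C5CCCCC5)c4c3)n2)cc1`, in this assay compound 2 gives 4.14%.

Compound 2 stands lowest of the two numbers shown, with compound 1 the nearer and higher of the pair; the one step measured, a number 33.7 percentage points lower from compound 1 to compound 2 (beyond the scatter), lies beyond the scatter.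

Compound 3, `FC(F)(F)c1cccc(-c2cn3ccnc3c(-c3ccc4ncn(C5CCCCC5)c4c3)n2)c1`, has not been measured. It differs from compound 2 in one place: 3-(trifluoromethyl)phenyl in place of 4-chlorophenyl on an aromatic carbon. Going by the values given here, the only measured step, from formyl to chloro, concerns a different group entering the same ring and so offers no direct guide to what a 3-(trifluoromethyl)phenyl does in place of a 4-chlorophenyl. What the numbers do show is that this ring is a place where a change can move the read-out by a large amount. Among the compounds with values here, with no step of the same kind to lean on, the expectation for compound 3 rests on its closeness to compound 2, and the step of a number 7.9 percentage points higher from compound 2 to compound 3 (within the scatter) is expected to stay within the scatter, with a wide range to allow for a rise. Compound 3 is thus estimated at 12%, between 0% and 35%.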

Compound 3, a percentage reported as inhibition, at one concentration (the size of the read-out at that concentration, not a potency): 4.38%
Beside the measured number, compound 3's estimate is 7.6 percentage points above it; the range from low to high includes it.
By their numbers in this assay, from the lowest: compounds 2 and 3 (each within the scatter of the next); then compound 1.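

In this assay, the exchange of 4-chlorophenyl for 3-(trifluoromethyl)phenyl gives a number 0.2 percentage points higher from compound 2 to compound 3 (within the scatter), so two aryl groups that differ in both substituent and its place on the phenyl ring cannot be told apart at this position. The new comparison with the formyl compound gives a number 33.4 percentage points lower from compound 1 to compound 3 (beyond the scatter), which shows that the gap first seen with the chloro compound is not unique to chlorine: among these three compounds, only compound 1, with its 4-formylphenyl, stands clearly apart. Nothing available explains why the formyl compound differs from the other two, or why the other two read alike.

On these data alone, whether the higher number of compound 1 depends on the formyl group itself stays open, and a carboxylic acid, a primary amide or an aminomethyl group on the phenyl ring would help to test this. An unsubstituted phenyl would show whether the chloro and trifluoromethyl compounds simply match the bare ring, and a 3-formylphenyl would separate the effect of the group from that of its place on the ring.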